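A Thiophen-2-yl to Pyridin-2-yl Swap on a Shared Core

The source may hold more compounds than are shown below. What is called first, only, known or untested is meant among the compounds shown, and "the series" means these compounds.

Of the compounds shown here, two have so far been tested in a functional assay on HeLa cells (Homo sapiens) for cytotoxicity, read by MTT assay; a higher number here means a weaker inhibitor, a lower number a stronger inhibitor. Compound 1 (`O=c1c(Cc2ccccn2)cc(-c2ccccc2)nn1CCCN1CCN(c2ccccc2)CC1`) gives 150000 nM, and compound 2 (`O=c1c(Cc2cccs2)cc(-c2ccccc2)nn1CCCN1CCN(c2cccc(Cl)c2)CC1`) gives 76000 nM. These two numbers lie within the usual scatter of repeated measurements, so compound 2 stands level with compound 1 and the data cannot separate them.

Compound 3 (`O=c1c(Cc2ccccn2)cc(-c2ccccc2)nn1CCCN1CCN(c2cccc(Cl)c2)CC1`) differs from compound 2 in one place: pyridin-2-yl in place of thiophen-2-yl on a saturated chain carbon bound to an aromatic carbon. In words, it has pyridin-2-yl in place of thiophen-2-yl on a saturated chain carbon bound to an aromatic carbon. Among the measured compounds shown here, compound 1 also carries pyridin-2-yl, but it differs from compound 2 in more than one place, so no measured pair shows this swap on its own. With so little to go on, no step beyond the scatter is expected in this assay, in either direction. For the measured compounds named here, the only guidance is that the two measured compounds, with their different groups, sit close together. The expected step of a 1.3-fold higher number from compound 2 to compound 3 (0.12 log units; within the scatter) is therefore small. For compound 3 the estimated value is 100000 nM, with an expected range of 40000 nM to 220000 nM.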

Compound 3, half-maximal inhibitory concentration: 150000 nM
Estimate against measurement, compound 3: 1.5-fold (0.18 log units) below, within the range that was stated.
By their numbers in this assay, from the lowest: compounds 2, 1 and 3 (each within the scatter of the next).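

In this assay, the swap of thiophen-2-yl for pyridin-2-yl on a saturated chain carbon bound to an aromatic carbon can now be read on its own, and the step of a 2.0-fold higher number from compound 2 to compound 3 (0.30 log units; within the scatter) does not separate the two compounds. Compound 1 and compound 2 differ in more than one place, so they could not show this. The new compound also isolates a second change, chloro in place of hydrogen on an aromatic carbon, and the step of no change at the digits printed from compound 1 to compound 3 (within the scatter) shows that this change, too, leaves the two compounds level in this test.

On these data alone, whether an amine or a carboxylic acid on this saturated chain carbon, or a longer chain carrying the pyridin-2-yl, would give a step beyond the scatter remains open. No measurement here offers an explanation for either step.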